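The source may report more compounds than this note shows. Statements on the series, on what has been measured and on what is new or still open speak of the compounds shown alone.

Measured in an ADME assay on CHO cells (Cricetulus griseus) for inhibition, read by MTT assay; on this read-out higher numbers stand for weaker inhibition and lower numbers for stronger inhibition:
- compound 1 `CCN(CC)Cc1cc(Nc2nc3ccccc3n2Cc2ccc(C(F)(F)F)cc2)ccc1O`: 17500 nM
- compound 2 `CCN(CC)Cc1c(Cl)ccc(Nc2nc3ccccc3n2Cc2ccc(C(F)(F)F)cc2)c1O`: > 50000 nM, a limit of the assay and not a number

Among the measured compounds shown here, compound 1 gives the only true number so far, 17500 nM, so it is the sole numerical reference for the series. Compound 3 `CCN(CC)Cc1cc(Nc2nc3ccccc3n2Cc2ccc(C#N)cc2)ccc1O` carries one change from compound 1: cyano in place of trifluoromethyl on an aromatic carbon, para to a large group. For the measured compounds named here, no measured step covers this change, so the expectation in this assay is modest, with a 1.3-fold higher number from compound 1 to compound 3 (0.10 log units; within the scatter) expected to stay within the scatter. Compound 3 is estimated at 22000 nM, with an expected range of 9000 nM to 50000 nM.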

Compound 3, half-maximal inhibitory concentration: > 50000 nM
Compound 3 was reported as a limit; the forecaster's own chance of this, stated with the estimate: 12%; at least 2.2-fold (0.35 log units) between middle value and limit.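

On the aromatic carbon para to a large group, cyano in place of trifluoromethyl is not a silent change in this assay; it gives an at least 2.8-fold higher number from compound 1 to compound 3 (0.45 log units; beyond the scatter). Compound 3 gives > 50000 nM, a limit of the assay and not a number. The step therefore fixes only a lower bound, and its full size stays unread: the limit of > 50000 nM in this assay, at which 2 of the 3 values shown sit.

On these data alone, whether an amine or a carboxylic acid on this aromatic carbon would return a true number remains open. A chlorine or methoxy group at the same place is equally unresolved.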